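The source may report more compounds than this note shows. Statements on the series, on what has been measured and on what is new or still open speak of the compounds shown alone.

The study concerns a shared core carrying a differently built side chain on the carbonyl carbon. Compound 1 `COc1cc(-c2nn(-c3cccc(NC(=O)c4cccc(C(F)(F)F)c4)c3)cc2-c2ccncc2)ccc1Cl` bears an aryl amide and in a functional assay on U-251 cells (Homo sapiens) for inhibition, read by sulforhodamine B assay, with a stated time of 48 h (on this read-out higher numbers stand for weaker inhibition of growth and lower numbers for stronger inhibition of growth), reaches only the assay limit of > 50000 nM, so no number is known for it. Compound 2 `COc1cc(-c2nn(-c3cccc(NC(=O)Nc4cccc(C(F)(F)F)c4)c3)cc2-c2ccncc2)ccc1Cl` carries a urea instead and gives 1370 nM in this assay. Within the data shown here, compound 3 `COc1cc(-c2nn(-c3cccc(NC(=O)Nc4ccc(Cl)c(C(F)(F)F)c4)c3)cc2-c2ccncc2)ccc1Cl` adds a chlorine to that urea and gives 4180 nM, the highest of the two numbers known, with compound 2 nearest (a 3.1-fold higher number from compound 2 to compound 3 (0.48 log units; beyond the scatter)). The two earlier steps were large: an at least 36-fold lower number from compound 1 to compound 2 (1.56 log units; beyond the scatter) and an at least 11-fold lower number from compound 1 to compound 3 (1.07 log units; beyond the scatter). Compound 4 `COc1cc(-c2nn(-c3cccc(NC(=O)c4ccccc4)c3)cc2-c2ccncc2)ccc1Cl` has not been measured; it differs from compound 3 in phenyl in place of (4-chloro-3-(trifluoromethyl)phenyl)amino on a carbonyl carbon, which removes the amino link again. Since the steps from compound 1 show that inserting the amino link lowered the number strongly, its removal is expected to raise it strongly, so the step from compound 3 to compound 4 is estimated as a 9.6-fold higher number from compound 3 to compound 4 (0.98 log units; beyond the scatter). For compound 4 the estimated value in this assay is 40000 nM, within 8000 nM to 200000 nM, with a real chance that only a limit is recorded.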

Compound 4, concentration for total growth inhibition: 30800 nM
For compound 4 the middle estimate is 1.3-fold (0.11 log units) above the measured one; low and high end bracket the measured number.
By their numbers in this assay, from the lowest: compound 2; then compound 3; then compound 4. At a limit, above all of these: compound 1.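

Compound 4 gives the amide series its first number, and that number still lies well above both ureas: a 7.4-fold higher number from compound 3 to compound 4 (0.87 log units; beyond the scatter) and a 22-fold higher number from compound 2 to compound 4 (1.35 log units; beyond the scatter). Replacing either substituted arylamino group on the carbonyl carbon with plain phenyl therefore weakens growth inhibition in both pairs shown, although each change removes the amino link and the ring substituents together. Removing trifluoromethyl from the amide gives an at least 1.6-fold lower number from compound 1 to compound 4 (0.21 log units; that floor lies within the scatter), and this is only a floor whose true size cannot be read, because compound 1 stands at a limit: the limit of > 50000 nM in this assay, at which 1 of the 4 values shown sits.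

As far as these compounds go, it remains open which part of the change carries the gap, since the amino link and the ring substituents are never varied apart on an otherwise unchanged side chain. From the compounds shown here alone, it is also open how an oxygen link, as in a carbamate, or a methylene link would read in this assay.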